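The compounds below may be only part of what the source reports. "The series", "measured", "known", "first", "only" and "open" are said of these compounds alone.

Compound 1, with the structure `CCCOC(=O)C1=C(C)N(C)C(=O)NC1c1ccoc1`, was tested in an assay on membranes from CHO cells for displacement of a labelled ligand from adenosine receptor A1 (Homo sapiens), read by scintillation counting, with a stated time of 60 min, tested at 1 uM (on this read-out higher numbers stand for more inhibition at the one concentration tested (going by the name of the read-out) and lower numbers for less inhibition), and gave 1%. Compound 2, `CCCOC(=O)C1=C(C)N(C)C(=O)NC1c1cccs1`, differs from it by one change, (thiophen-2-yl in place of furan-3-yl on a saturated ring carbon), and in this assay compound 2 gave 9%; the step of a number 8 percentage points higher from compound 1 to compound 2 (within the scatter) is within the scatter, so the two numbers cannot be told apart.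

Compound 3 has the structure `CCNC(=O)C1=C(C)NC(=O)NC1c1ccoc1` and in this assay gave 1%, level with compound 1 at the digits printed and together with it the lowest of the three numbers. How the core of compound 3 differs from the core of compound 1 is not broken down here.

Compound 4, `CCNC(=O)C1=C(C)NC(=O)NC1c1cccs1`, has not yet been measured. It stands to compound 3 as compound 2 stands to compound 1: the change is thiophen-2-yl in place of furan-3-yl on a saturated ring carbon. The surroundings are not the same word for word, since in compound 3 the saturated ring carbon is next to the ring atom that bears an ethylcarbamoyl group, whereas in compound 1 it is next to the ring atom that bears a propoxycarbonyl group; it is therefore the same kind of change rather than the same change.

Given that the earlier step of a number 8 percentage points higher from compound 1 to compound 2 (within the scatter) stayed within the scatter, the step of a number 5 percentage points higher from compound 3 to compound 4 (within the scatter) is expected to be of similar small size. Compound 4 is therefore estimated to give about 6%, most likely between -5% and 17%.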

Compound 4, a percentage reported as inhibition, at one concentration (the size of the read-out at that concentration, not a potency): 1%
Estimate against measurement, compound 4: 5 percentage points above; low and high end bracket the measured number.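

In this assay, putting thiophen-2-yl in place of furan-3-yl on a saturated ring carbon gives no change at the digits printed from compound 3 to compound 4 (within the scatter). Set beside the earlier step, the same change shows no difference between the two cores that this read-out can resolve: the same change on two cores in this assay, a number 8 percentage points higher (within the scatter) from compound 1 to compound 2 and no change at the digits printed (within the scatter) from compound 3 to compound 4, 8 percentage points apart, within the scatter of two such steps. Going by these compounds alone, this shows only that the change, on these two cores, produced no step that stands out from the scatter; it does not show that the change is without any effect, nor that its effect is truly the same on both cores, since each step rests on a single pair of compounds, tested at one concentration, and all four numbers lie at the low end of the read-out, which says little about how the change would behave on a compound giving a much larger number.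

The compounds shown leave open whether a different group on the saturated ring carbon, such as an amine or a carboxylic acid, would give a number beyond the scatter of these four. They also leave open whether a longer chain in place of the ethylcarbamoyl or propoxycarbonyl group would alter what this change does.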